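Selenium in Place of Sulfur: Expected Cytotoxicity Shift

A few compounds are considered here, and "the series" means these few. Any claim that something is new, unique, unknown or untested is made for them only; others in the source may bear on it.

Compound 1 `CS/C(=N\C(=O)c1ccccc1)NC(=O)c1ccccc1` and compound 2 `C[Se]/C(=N\C(=O)c1ccccc1)NC(=O)c1ccccc1` share one core and differ in a single place. In a functional assay on PC-3 cells (Homo sapiens) for cytotoxicity, read by MTT assay (on this read-out lower numbers stand for stronger inhibition and higher numbers for weaker inhibition), compound 1 reaches only a limit of the assay, recorded as > 10000 nM. In this assay compound 2 gives 2500 nM. The change a group of 2 heavy atoms (1 carbon, 1 selenium; no ring) in place of a group of 2 heavy atoms (1 carbon, 1 sulfur; no ring), on a carbon with a double bond to nitrogen produced a step of an at least 4.0-fold lower number from compound 1 to compound 2 (0.60 log units; beyond the scatter), and the true size of that step is hidden by the limit of > 10000 nM in this assay, at which 2 of the 3 values shown sit. Compound 3 `CS/C(=N\C(=O)c1ccc(Cl)cc1)NC(=O)c1ccc(Cl)cc1` carries a different core; the difference between the two cores is not broken down here. In this assay compound 3 reaches only a limit of the assay, recorded as > 10000 nM. Compound 4 `C[Se]/C(=N\C(=O)c1ccc(Cl)cc1)NC(=O)c1ccc(Cl)cc1` is not yet measured and arises through (a group of 2 heavy atoms (1 carbon, 1 selenium; no ring) in place of a group of 2 heavy atoms (1 carbon, 1 sulfur; no ring), on a carbon with a double bond to nitrogen), the same change at the same place. The step is expected to be about an at least 2.8-fold lower number from compound 3 to compound 4 (0.45 log units; beyond the scatter), resting on the earlier step of an at least 4.0-fold lower number from compound 1 to compound 2 (0.60 log units; beyond the scatter). Compound 4 is therefore estimated at 3500 nM, expected between 1200 nM and 12000 nM.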

Compound 4, half-maximal inhibitory concentration: 7600 nM
Compound 4: middle estimate off by 2.2-fold (0.34 log units), on the low side; the range from low to high includes it.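

In this assay, carrying the change to the core of compound 3 gives a step of an at least 1.3-fold lower number from compound 3 to compound 4 (0.11 log units; that floor lies within the scatter), so this step can be read only as a floor. On both cores the selenium compound gives a measured value while its sulfur partner stays at a limit, but this does not show that the change has the same size on each core: the same change on two cores in this assay, an at least 4.0-fold lower number (0.60 log units; beyond the scatter) from compound 1 to compound 2 and an at least 1.3-fold lower number (0.11 log units; that floor lies within the scatter) from compound 3 to compound 4; the limit leaves it open whether they differ The true size of both steps stays hidden, and a firm comparison would need real numbers for the sulfur compounds: the limit of > 10000 nM in this assay, at which 2 of the 4 values shown sit.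

The compounds shown leave open how the change behaves on a core with methoxy or a nitrile in place of the chlorine. They also leave open whether it holds when a longer chain, such as ethyl, replaces the methyl on sulfur and selenium.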